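The source may report more compounds than this note shows. Statements on the series, on what has been measured and on what is new or still open speak of the compounds shown alone.

Compound 3 `Cc1cc(NC(=O)CC2CCCCC2)nn1Cc1cc(Cl)ccc1OCc1ccccc1` stands lowest of the three numbers measured in an assay on CHO-K1 cells for displacement of a labelled ligand from prostaglandin E2 receptor EP1 subtype (Homo sapiens) (a lower number here means a stronger inhibitor, a higher number a weaker inhibitor), giving 6.31 nM. Compound 2 `Cc1cc(NC(=O)C2CCCC2)nn1Cc1cc(Cl)ccc1OCc1ccccc1` gives 15.9 nM, and compound 1 `CC(=O)Nc1cc(C)n(Cc2cc(Cl)ccc2OCc2ccccc2)n1` gives 316 nM. Compound 4 `COC(=O)Nc1cc(C)n(Cc2cc(Cl)ccc2OCc2ccccc2)n1` differs from compound 3 by methoxy in place of cyclohexylmethyl on a carbonyl carbon. Among the compounds with values here, the steps that bear on this change all run the other way: a 20-fold lower number from compound 1 to compound 2 (1.30 log units; beyond the scatter), a 50-fold lower number from compound 1 to compound 3 (1.70 log units; beyond the scatter) and a 2.5-fold lower number from compound 2 to compound 3 (0.40 log units; beyond the scatter). In each of them a ring-bearing group arrived on or near the carbonyl carbon and the number fell; here the ring leaves and methoxy enters, so a large step upward is expected, to about the value of compound 1 or somewhat beyond it. For compound 4 the estimate is 450 nM, between 150 nM and 1500 nM. The expected step is thus a 71-fold higher number from compound 3 to compound 4 (1.85 log units; beyond the scatter).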

Compound 4, half-maximal inhibitory concentration: 200 nM
For compound 4 the middle estimate is 2.3-fold (0.35 log units) above the measured one; low and high end bracket the measured number.
By their numbers in this assay, from the lowest: compound 3; then compound 2; then compounds 4 and 1 (each within the scatter of the next).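

In this assay the change from methyl to methoxy on the carbonyl carbon gives a 1.6-fold lower number from compound 1 to compound 4 (0.20 log units; within the scatter) and so does not separate these two small groups. Replacing a ring-bearing group with methoxy gives a 32-fold higher number from compound 3 to compound 4 (1.50 log units; beyond the scatter) and a 13-fold higher number from compound 2 to compound 4 (1.10 log units; beyond the scatter) as well, so the advantage of those groups holds against an oxygen-linked group as it did against methyl.

Nothing shown accounts for these differences and the compounds leave open how a longer open chain, an amine or a phenyl group on the carbonyl carbon would compare.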